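The source may hold more compounds than are shown below. What is called first, only, known or untested is meant among the compounds shown, and "the series" means these compounds.

In a functional assay on CHO cells with adenosine receptor A1 (Homo sapiens) as the target, read by cAMP accumulation and immunoassay, with a stated time of 6 min, tested at 0.01 uM (on this read-out higher numbers stand for a weaker effect at the one concentration tested and lower numbers for a stronger effect), compound 1 `Nc1scc(CN2CCN(c3ccc(Cl)cc3Cl)CC2)c1C(=O)c1ccc(Cl)cc1` gives 2%, compound 2 `Nc1scc(CN2CCN(c3cc(Cl)cc(Cl)c3)CC2)c1C(=O)c1ccc(Cl)cc1` gives -1% and compound 3 `Nc1scc(CN2CCN(c3ccccc3C(F)(F)F)CC2)c1C(=O)c1ccc(Cl)cc1` gives 0%. Compound 2 holds the lowest of the three numbers, though a number 3 percentage points lower from compound 1 to compound 2 (within the scatter) and a number 1 percentage points higher from compound 2 to compound 3 (within the scatter) both stay within the scatter, as does a number 2 percentage points lower from compound 1 to compound 3 (within the scatter); all three compounds sit at a level of essentially no effect at this concentration. Compound 4 `Nc1scc(CN2CCN(c3ccc(Cl)c(C(F)(F)F)c3)CC2)c1C(=O)c1ccc(Cl)cc1` carries 4-chloro-3-(trifluoromethyl)phenyl in place of 3,5-dichlorophenyl on an amine nitrogen in a ring. The measured steps that bear on it are the three exchanges of the group on the amine nitrogen in the ring, each within the scatter, so no step beyond the scatter is expected in this assay here either. Compound 4 is therefore expected near 1%, between -9% and 11%, meaning an estimated a number 2 percentage points higher from compound 2 to compound 4 (within the scatter).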

Compound 4, a percentage reported as activity, at one concentration (the size of the read-out at that concentration, not a potency): -2.5%
Estimate against measurement, compound 4: 3.5 percentage points above; the measured number falls inside the stated range.
By their numbers in this assay, from the lowest: compounds 4, 2, 3 and 1 (each within the scatter of the next).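

With 4-chloro-3-(trifluoromethyl)phenyl on the amine nitrogen in the ring, this assay shows a number 1.5 percentage points lower from compound 2 to compound 4 (within the scatter) together with a number 2.5 percentage points lower from compound 3 to compound 4 (within the scatter) and a number 4.5 percentage points lower from compound 1 to compound 4 (within the scatter) so chlorine and trifluoromethyl on one phenyl ring give no step beyond the scatter from either kind of group alone. The exchange from 8 to 11 heavy atoms also leaves the number within the scatter of all three earlier compounds. No measurement on hand offers a reason for this flat result. Open, as far as these compounds go, is whether an amine or a carboxylic acid on the phenyl ring would move the number at this position.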